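The compounds below may be only part of what the source reports. "The series", "measured", "known", "first", "only" and "open" are said of these compounds alone.

Among the compounds with values here, in a functional assay on MGC-803 cells (Homo sapiens) for cytotoxicity, read by MTT assay, with a stated time of 72 h (on this read-out lower numbers stand for stronger inhibition and higher numbers for weaker inhibition), three compounds have numbers so far. Compound 1 `O=C(CSC(=S)N[C@H]1CCOC1=O)Nc1ccc(Cl)cc1Cl` gives 48500 nM, and compound 2 `CCOC(=O)c1ccc(NC(=O)CSC(=S)N[C@H]2CCOC2=O)cc1` gives 21700 nM. Compound 3 `O=C(CCl)Nc1ccc(C(=O)/C=C/c2ccccc2)cc1` gives 6940 nM, the lowest of the three and beyond the scatter of repeat measurements against each of the others. Compound 4 `O=C(CCl)Nc1ccc(C(=O)/C=C/c2cccc(Cl)c2)cc1` has not yet been measured. It differs from compound 3 by one small edit, (chloro in place of hydrogen on an aromatic carbon), which turns phenyl to 3-chlorophenyl. Within the data shown here, no measured pair here shows what such an edit does, so the expectation rests on compound 3 and its 6940 nM. The estimated change is small and within the scatter, slightly toward stronger inhibition: a 1.4-fold lower number from compound 3 to compound 4 (0.14 log units; within the scatter). For compound 4 the expected value is 5000 nM, with an estimated range of 2000 nM to 12000 nM.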

Compound 4, half-maximal inhibitory concentration: 2010 nM
The estimate for compound 4 lay 2.5-fold (0.40 log units) above the measured number; measured number inside the range.
By their numbers in this assay, from the lowest: compound 4; then compound 3; then compound 2; then compound 1.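

In this assay, within the data shown here, the change from phenyl to 3-chlorophenyl gives a 3.5-fold lower number from compound 3 to compound 4 (0.54 log units; beyond the scatter) and is the first single-place change that can be read here. It shows that on this ring, a chloro group on the carbon meta to a large group moves the number toward stronger inhibition by more than the scatter. No measurement here bears on why the number falls.

On these data alone, with one step, it remains open whether this is specific to chloro or to this carbon. A methoxy group or an amine at the same carbon could give a different number, and so could chloro on another carbon of the ring.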